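Swapping the amide of compound 2 for a hydroxymethyl group

A few compounds are considered here, and "the series" means these few. Any claim that something is new, unique, unknown or untested is made for them only; others in the source may bear on it.

Of the compounds shown here, two sharing one core have been tested in a functional assay on the whole organism (blood, strain ICR) with Mus musculus as the target, in the glucose tolerance test, with a stated time of 30 min; a higher number here means that more compound is needed for the effect, a lower number that less compound is needed. Compound 1 `CNC(=O)C1CCN(c2nc(-c3cc(F)c(Cl)cc3F)nc3c2CS(=O)(=O)C3)CC1` gives 3 mg/kg. Among the compounds with values here, compound 2 `CN(C)C(=O)C1CCN(c2nc(-c3cc(F)c(Cl)cc3F)nc3c2CS(=O)(=O)C3)CC1` gives 1 mg/kg, the lowest of the two numbers, and the only measured step, a 3.0-fold lower number from compound 1 to compound 2 (0.48 log units; beyond the scatter), lies beyond the scatter. Compound 3 `O=S1(=O)Cc2nc(-c3cc(F)c(Cl)cc3F)nc(N3CCC(CO)CC3)c2C1` has not been measured yet. It differs from compound 2 in one place: hydroxymethyl in place of dimethylcarbamoyl on a saturated ring carbon. Within the data shown here, the single known step changed only the substituent on the amide-type nitrogen, whereas here the whole dimethylcarbamoyl leaves and a hydroxymethyl enters, so that step offers little guidance. Among the measured compounds shown here, no measured compound carries a hydroxymethyl, and nothing in the data shows how that group behaves. The expectation is therefore cautious: compound 3 is estimated at 3 mg/kg, within 1 mg/kg to 10 mg/kg, which corresponds to an expected step of a 3.0-fold higher number from compound 2 to compound 3 (0.48 log units; beyond the scatter).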

Compound 3, minimum effective dose in the Mus musculus assay: 0.3 mg/kg
Estimate against measurement, compound 3: 10-fold (1.00 log units) above; the whole stated range lies above it.
By their numbers in the Mus musculus assay, from the lowest: compound 3; then compound 2; then compound 1.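

In the Mus musculus assay, the whole amide can leave this ring carbon without any loss, as hydroxymethyl gives a 3.3-fold lower number from compound 2 to compound 3 (0.52 log units; beyond the scatter) and a 10-fold lower number from compound 1 to compound 3 (1.00 log units; beyond the scatter), so among these three compounds a carbonyl at this position is not needed for a low effective dose. In a physicochemical assay for solubility, with a stated time of 20 h, at pH 6.8 (on this read-out higher numbers stand for higher solubility and lower numbers for lower solubility), compound 2 gives > 100000 nM, which is a limit of the assay and not a number: the limit of > 100000 nM in the physicochemical assay, at which 1 of the 2 values shown sits. In the physicochemical assay, compound 3 gives 16000 nM, so the same change that lowers the dose also brings an at least 6.2-fold lower number from compound 2 to compound 3 (0.79 log units; beyond the scatter).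

On these data alone, whether the hydroxyl itself matters, or only the loss of the amide, stays open, and a methoxymethyl group, a longer hydroxyalkyl chain or a carboxylic acid at this position would help to separate the two. Also open, as far as these compounds go, is whether any group here can combine the low dose of compound 3 with the read-out of compound 2.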